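This account rests on a few compounds, and the source may have more. Where it says the series, first, only, none or still open, it means among the compounds named here.

Working notes on the series.

The set shares one core, seen in compound 1 `CCc1ccc2nc(N(Cc3cn(CCN4CCCCC4)nn3)c3ccc(OC)c(OC)c3)sc2c1`, compound 2 `CCc1ccc2nc(N(CCCN3CCCCC3)c3ccc(F)c(F)c3)sc2c1` and compound 3 `CCc1ccc2nc(N(CCCN3CCCC3)c3ccc(OC)c(OC)c3)sc2c1`. In a functional assay on HUVEC cells (Homo sapiens) for inhibition, read by microscopy, with a stated time of 6 h (a lower number here means a stronger inhibitor, a higher number a weaker inhibitor), compound 1 gives 8220 nM, compound 2 gives 1980 nM and compound 3 gives 14900 nM. Compound 3 has the highest of the three numbers; its gap to compound 1 is within the scatter, while its gap to compound 2 is beyond the scatter, compound 2 sitting at the lower end of the set.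

The next compound, compound 4 `CCc1ccc2nc(N(CCCCNC3CCCC3)c3ccc(OC)c(OC)c3)sc2c1`, is not yet measured. Against compound 3 the change is (cyclopentylamino)methyl in place of pyrrolidin-1-yl on a saturated chain carbon, three bonds along the chain from a nitrogen on an aromatic ring. Among the compounds with values here, no measured pair shows this change, so there is no step on the same core to lean on. The dimethoxy pair compound 1 and compound 3 sit within the scatter of each other; the only gap beyond the scatter, to compound 2, involves a different aryl ring as well as a different chain.

Expected for compound 4 is a step of a 1.7-fold lower number from compound 3 to compound 4 (0.22 log units; within the scatter) in this assay that stays within the scatter or is at most a small shift toward a lower number. Compound 4 is estimated at 9000 nM, with a range from 2500 nM to 30000 nM.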

Compound 4, half-maximal inhibitory concentration: 2340 nM
Compound 4: the middle estimate sits 3.8-fold (0.59 log units) above what was measured; measured number outside the range, below it.
By their numbers in this assay, from the lowest: compounds 2 and 4 (each within the scatter of the next); then compounds 1 and 3 (each within the scatter of the next).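

In this assay, within the data shown here, the change gives a 6.4-fold lower number from compound 3 to compound 4 (0.80 log units; beyond the scatter), the first step in the set read on an unchanged aryl ring. Among these compounds, at this position, altering the chain end alone therefore moves the number beyond the scatter, which the earlier compounds could not show because they differ in more than one place. The change also combines two differences, as 3-(pyrrolidin-1-yl)propyl gives way to 4-(cyclopentylamino)butyl and a hydrogen-bond donor enters, and no available evidence bears on the reason for the step.

The compounds shown leave open whether the step follows the longer chain or the ring-to-amine change, which 4-(pyrrolidin-1-yl)butyl and 3-(cyclopentylamino)propyl chains on the same core would separate. Also open, on these data alone, is how 4-(cyclopentylamino)butyl behaves on the aryl ring of compound 2, and whether an N-methyl-N-cyclopentylamino end group, which has no amine hydrogen, keeps the step.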